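Swapping a trifluoromethylphenyl for a methoxyphenyl

This account rests on a few compounds, and the source may have more. Where it says the series, first, only, none or still open, it means among the compounds named here.

Of the compounds shown here, three sharing one core have been measured in a functional assay on MCF7 cells (Homo sapiens) for antiproliferative activity, read by MTT assay, with a stated time of 72 h; a higher number here means a weaker inhibitor, a lower number a stronger inhibitor. Compound 1, `COc1cc(-n2cnc3ccc(-c4ccc(C(F)(F)F)cc4)cc32)cc(OC)c1OC`, gives 760 nM, the lowest of the two numbers recorded. Compound 2, `COc1cc(-n2cnc3ccc(-c4cccc(F)c4)cc32)cc(OC)c1OC`, gives 2350 nM. Compound 3, `COc1cc(-c2ccc3ncn(-c4cc(OC)c(OC)c(OC)c4)c3c2)cc(OC)c1OC`, reaches only the limit of > 10000 nM, so no number is known for it. Within the data shown here, the one step between measured compounds with a single difference is a 3.1-fold higher number from compound 1 to compound 2 (0.49 log units; beyond the scatter), meaning the 3-fluorophenyl compound is a modestly weaker inhibitor than the 4-(trifluoromethyl)phenyl compound.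

Compound 4, `COc1cccc(-c2ccc3ncn(-c4cc(OC)c(OC)c(OC)c4)c3c2)c1`, has not yet been measured. It differs from compound 1 by 3-methoxyphenyl in place of 4-(trifluoromethyl)phenyl on an aromatic carbon. The step from compound 1 to compound 2 bears on this change, since both replace 4-(trifluoromethyl)phenyl with a differently substituted phenyl; it was beyond the scatter and made the number higher. Compound 3, carrying a methoxy-rich phenyl, sat at the limit (the limit of > 10000 nM in this assay, at which 1 of the 3 values shown sits). Compound 4 is therefore expected to be a weaker inhibitor than compound 1, with a step of roughly a 3.3-fold higher number from compound 1 to compound 4 (0.52 log units; beyond the scatter). The estimated value for compound 4 is 2500 nM, within a range from 900 nM to 8000 nM.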

Compound 4, half-maximal inhibitory concentration: 1610 nM
Estimate against measurement, compound 4: 1.6-fold (0.19 log units) above, and the stated range covers the measured number.
By their numbers in this assay, from the lowest: compound 1; then compounds 4 and 2 (each within the scatter of the next). At a limit, above all of these: compound 3.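

In this assay, methoxy and fluoro on this phenyl cannot be told apart, since the step between them is small: a 1.5-fold lower number from compound 2 to compound 4 (0.16 log units; within the scatter). Compound 1 keeps its lead over this new substituent too, but the loss is modest: a 2.1-fold higher number from compound 1 to compound 4 (0.33 log units; beyond the scatter), so a single methoxy on the phenyl still gives a measured number. Compound 3, with its methoxy-rich phenyl, is the only compound that gives a limit rather than a number: the limit of > 10000 nM in this assay, at which 1 of the 4 values shown sits.

The compounds shown leave open whether the lead of compound 1 belongs to the trifluoromethyl group itself or to where it sits on the phenyl, with the 3-substituted and 4-substituted rings here carrying different groups. Going by these compounds, how an amine or a carboxylic acid on this phenyl would behave also remains open.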